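The compounds below may be only part of what the source reports. "The series", "measured", "known", "first", "only" and "open" are said of these compounds alone.

In an ADME assay on HepG2 cells (Homo sapiens) for cytotoxicity, read by CellTiter-Glo, with a stated time of 48 h (on this read-out lower numbers stand for higher toxicity in this test and higher numbers for lower toxicity in this test), compound 1 `CCCCNc1nc2ccccc2nc1S(C)(=O)=O` gives 12600 nM and compound 3 `CCCCNc1nc2cc(Cl)ccc2nc1S(C)(=O)=O` gives 6310 nM. These two numbers cannot be told apart within the usual scatter. Compound 4 `CS(=O)(=O)c1nc2ccc(Cl)cc2nc1NC1CCCCC1` keeps the core and the chloro group of compound 3 and makes one change: cyclohexyl in place of butyl on a nitrogen on an aromatic ring. Put simply, butylamino gives way to cyclohexylamino.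

Within the data shown here, the only measured step, a 2.0-fold lower number from compound 1 to compound 3 (0.30 log units; within the scatter), swaps hydrogen for chloro and stays within the scatter. Among the measured compounds shown here, it leaves the butyl group untouched, so no measured step shows this change directly. The nearest clue is compound 2 `COc1ccc2nc(S(C)(=O)=O)c(NC3CCCCC3)nc2c1`, which carries cyclohexylamino and gives 79400 nM, a much higher number than that of compound 3. However, compound 2 also has methoxy where compound 3 has chloro, so only part of that gap can be expected to carry over.

The expected change is a 3.2-fold higher number from compound 3 to compound 4 (0.50 log units; beyond the scatter), an estimated move towards lower toxicity in this assay. For compound 4 the estimate is 20000 nM, with an expected range of 6000 nM to 70000 nM.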

Compound 4, half-maximal cytotoxic concentration: 5010 nM
For compound 4 the middle estimate is 4.0-fold (0.60 log units) above the measured one; the whole stated range lies above it.
By their numbers in this assay, from the lowest: compounds 4, 3 and 1 (each within the scatter of the next, the first and the last beyond it); then compound 2.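

In this assay, with the chloro group held in place, cyclohexyl in place of butyl on a nitrogen on an aromatic ring gives only a small step (a 1.3-fold lower number from compound 3 to compound 4 (0.10 log units; within the scatter)), so compound 3 and compound 4 cannot be told apart. With cyclohexylamino held in place, chloro in place of methoxy on an aromatic carbon gives a large step (a 16-fold lower number from compound 2 to compound 4 (1.20 log units; beyond the scatter)), so the wide gap between compound 2 and compound 4 goes with that swap and not with the amine chain. No measurement given here explains this difference in size.

As far as these compounds go, whether butyl and cyclohexyl also match when methoxy replaces chloro remains open. From the compounds shown here alone, it is equally open whether a longer chain or a phenyl group on that nitrogen would match them, and whether fluoro or a nitrile on that aromatic carbon would sit nearer chloro or methoxy.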